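The compounds below may be only part of what the source reports. "The series", "measured", "known", "first", "only" and "open" are said of these compounds alone.

In an ADME assay on a cell-free system (plasma, Homo sapiens) for protein binding (a lower number here means a smaller unbound share, a higher number a larger unbound share of the compound), compound 1 `COc1ccccc1C1CCN(c2ccn3c(CC4CC4)nnc3c2Cl)CC1` gives < 0.01, which is a limit of the assay. Compound 2 `COc1c(F)cccc1C1CCN(c2ccn3c(CC4CC4)nnc3c2Cl)CC1` gives < 0.01, again a limit. The step that the two limits leave unreadable from compound 1 to compound 2 cannot be sized, since both values sit at the limit of < 0.01 in this assay, at which 2 of the 2 values shown sit. Compound 3 `COc1c(F)cccc1C1CCN(c2ccn3c(CC4CC4)nnc3c2C(F)(F)F)CC1` differs from compound 2 by trifluoromethyl in place of chloro on an aromatic carbon. For the measured compounds named here, no measured step resolves a change of this kind, and the two limits give no direction for it. Compound 3 is expected to stay at the limit, with an estimated step that the limit leaves unreadable from compound 2 to compound 3 no larger than the scatter. The estimate for compound 3 is 0.005, within 0.001 to 0.012.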

Compound 3, unbound fraction: < 0.01
Compound 3 ended at the assay's limit (the forecaster's own chance of this, stated with the estimate: 85%); the middle value does not contradict the limit.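

No step can be read from compound 2 to compound 3, since both values are limits of the assay: the limit of < 0.01 in this assay, at which 3 of the 3 values shown sit. As far as these compounds go, whether trifluoromethyl in place of chloro changes the unbound fraction at all, and in which direction, stays open.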